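The compounds below may be only part of what the source reports. "The series", "measured", "known", "first", "only" and "open" are said of these compounds alone.

Measured compounds:
compound 1 `NS(=O)(=O)c1ccc(N2N=C(c3ccc(Oc4ccccc4)cc3)CC2c2ccccc2Cl)cc1` — 40000 nM
compound 2 `Cc1ccccc1C1CC(c2ccc(Oc3ccccc3)cc2)=NN1c1ccc(S(N)(=O)=O)cc1` — 36000 nM

In an ADME assay on MT4 cells (Homo sapiens) for cytotoxicity, read by MTT assay, with a stated time of 96 h (a lower number here means that less compound is tolerated, a higher number that more compound is tolerated), compound 1 gives 40000 nM, the highest of the two numbers shown. Its nearest neighbour is compound 2, which in this assay gives 36000 nM; the step of a 1.1-fold lower number from compound 1 to compound 2 (0.05 log units; within the scatter) lies within the scatter, so the two compounds cannot be told apart on these numbers.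

Compound 3 `NS(=O)(=O)c1ccc(N2N=C(c3ccccc3)CC2c2ccccc2Cl)cc1` has not yet been measured in this assay. It differs from compound 1 in one place: hydrogen in place of phenoxy on an aromatic carbon. Among the compounds with values here, the single measured step, from compound 1 to compound 2, concerns a methyl in place of chloro on an aromatic carbon and not the phenoxy, so no measured step bears directly on this change. What the data do show is that the two measured compounds, which share the phenoxy, sit close together.

Within the data shown here, with no step to lean on, compound 3 is expected to stay near compound 1, and the estimated step is a 1.1-fold higher number from compound 1 to compound 3 (0.05 log units; within the scatter), which is not beyond the scatter. For compound 3 the estimate in this assay is 45000 nM, with a range from 20000 nM to 100000 nM.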

Compound 3, half-maximal cytotoxic concentration: 44000 nM
Beside the measured number, compound 3's estimate is 1.0-fold (0.01 log units) above it; the measured number falls inside the stated range.
By their numbers in this assay, from the lowest: compounds 2, 1 and 3 (each within the scatter of the next).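

With hydrogen in place of phenoxy on an aromatic carbon, para to a large group, this assay gives a 1.1-fold higher number from compound 1 to compound 3 (0.04 log units; within the scatter), so this position can lose the whole phenoxy, with its six-membered aromatic ring of carbon only, without a change that can be read in this assay. The earlier pair showed only that methyl in place of chloro on an aromatic carbon left the number within the scatter while the phenoxy stayed in place; this new step shows the same for a much larger change in heavy atoms, at a different place on the molecule, so neither of the two single changes seen so far separates its compounds. Nothing at hand explains why the number stays put at this position.

Going by these compounds, what an amine or a carboxylic acid on this same aromatic carbon would give in this assay remains open, as does whether a longer chain there would move the number beyond the scatter. On these data alone, it is also open whether hydrogen in place of phenoxy would behave the same way with methyl rather than chloro on the other aromatic ring.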